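The source may hold more compounds than are shown below. What is called first, only, known or untested is meant among the compounds shown, and "the series" means these compounds.

Measured so far in a physicochemical assay for solubility, read by nephelometry, at pH 7.4; a higher number here means a more soluble compound, a lower number a less soluble compound:
- compound 1, `COc1cccc(NC(=O)c2nnn(Cc3ccc(C(C)C)cc3)c2N)c1`: 14000 nM
- compound 2, `COc1cccc(NC(=O)c2nnn(Cc3ccc(C#N)cc3)c2N)c1`: 216000 nM

Among the measured compounds shown here, compound 2 stands highest of the two numbers in this assay; the nearest is compound 1, and the only measured step, a 15-fold higher number from compound 1 to compound 2 (1.19 log units; beyond the scatter), is large and beyond the scatter. That step is the one that bears on the present change, since both concern the same aromatic carbon: the cyano that entered there in that step now leaves.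

Compound 3, `COc1cccc(NC(=O)c2nnn(Cc3ccc([S+](C)[O-])cc3)c2N)c1`, differs from compound 2 by a group of 3 heavy atoms (1 carbon, 1 oxygen, 1 sulfur; no ring) in place of a group of 2 heavy atoms (1 carbon, 1 nitrogen; no ring), on an aromatic carbon. No measured compound carries the entering group, so its effect in this assay is not shown by any step. For the measured compounds named here, the single step available shows the cyano at this position sitting high; its removal is the part that is informed, the entering group is not.

A lower number than compound 2 is therefore expected for compound 3, though well short of a return to the number of compound 1, and the range is kept wide: the expected step is a 2.2-fold lower number from compound 2 to compound 3 (0.33 log units; beyond the scatter), with the estimate for compound 3 at 100000 nM (range 25000 nM to 400000 nM).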

Compound 3, solubility: > 250000 nM
Compound 3 ended at the assay's limit (the forecaster's own chance of this, stated with the estimate: 5%); middle value at least 2.5-fold (0.39 log units) from the limit.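

In this assay the value of compound 3 is a limit of the assay and not a number: the limit of > 250000 nM in this assay, at which 1 of the 3 values shown sits. Putting the group of 3 heavy atoms (1 carbon, 1 oxygen, 1 sulfur) in place of cyano gives an at least 1.1-fold higher number from compound 2 to compound 3 (0.06 log units; that floor lies within the scatter); that floor lies within the scatter, so the step sets no order between the two groups, though it shows no fall on leaving cyano, which the earlier pair could not show. Against isopropyl on the same aromatic carbon the step is an at least 17-fold higher number from compound 1 to compound 3 (1.25 log units; beyond the scatter), large and beyond the scatter, so cyano is no longer the only group at this position shown to sit far from the isopropyl number.

As far as these compounds go, how far compound 3 lies past the limit stays open, and with it any ranking against compound 2 in this read-out. Also open, from the compounds shown here alone, is whether the high numbers at this aromatic carbon extend to other groups there, such as an amine, a carboxylic acid or a longer chain, and whether they hold on any change to the shared core.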